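Adding trifluoromethyl to compound 3: an expected shift

The source may report more compounds than this note shows. Statements on the series, on what has been measured and on what is new or still open speak of the compounds shown alone.

Compound 1 `O=C(O)c1cn(C2CC2)c2c(C(F)(F)F)c(N3CCCC3)c(F)cc2c1=O` gives 280 ug/mL
Compound 2 `CCNCC1CCN(c2c(F)cc3c(=O)c(C(=O)O)cn(C4CC4)c3c2C(F)(F)F)C1` gives 120 ug/mL
Compound 3 `CC1CN(c2cc3c(cc2F)c(=O)c(C(=O)O)cn3C2CC2)CC(C)N1` gives > 500 ug/mL (a limit)

All three values come from a functional assay on V79 cells (Cricetulus griseus) for cytotoxicity, read by colony formation (on this read-out higher numbers stand for weaker inhibition and lower numbers for stronger inhibition), and compound 3 has only a limit there (> 500 ug/mL), not a number.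

Compound 4 `CC1CN(c2c(F)cc3c(=O)c(C(=O)O)cn(C4CC4)c3c2C(F)(F)F)CC(C)N1` keeps the 3,5-dimethylpiperazin-1-yl group of compound 3 and differs from it by one change (trifluoromethyl in place of hydrogen on an aromatic carbon), trifluoromethyl in place of hydrogen on an aromatic carbon.

Going by the values given here, the only measured step (a 2.3-fold lower number from compound 1 to compound 2 (0.37 log units; beyond the scatter)) is a different change, (ethylamino)methyl in place of hydrogen on a saturated ring carbon. Among the compounds with values here, it shows how far a side-chain change moved the number among compounds already carrying trifluoromethyl, but no measured step tests the trifluoromethyl exchange itself.

The nearest guide is therefore the pair of values for those compounds, compound 1 (280 ug/mL) and compound 2 (120 ug/mL). Within the data shown here, both give numbers, whereas the one compound without trifluoromethyl reaches the limit. On that slender basis, a lower number is expected for compound 4, though a limit remains possible.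

The expected change is an at least 2.5-fold lower number from compound 3 to compound 4 (0.39 log units; beyond the scatter) (an estimate that starts from a limit).

The estimated value for compound 4 is 200 ug/mL (expected range 70 ug/mL to 500 ug/mL).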

Compound 4, half-maximal inhibitory concentration: > 500 ug/mL
Compound 4 gave a limit, no number (the forecaster's own chance of this, stated with the estimate: 15%); middle value at least 2.5-fold (0.39 log units) from the limit.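

In this assay compound 4 gives only a limit, > 500 ug/mL, so carrying trifluoromethyl on this aromatic carbon does not by itself yield a number, something that compound 1 and compound 2 alone could not show. Compound 3 also gives only a limit, so the step for trifluoromethyl in place of hydrogen cannot be read, and no size can be assigned to this change: the limit of > 500 ug/mL in this assay, at which 2 of the 4 values shown sit. Among the compounds carrying trifluoromethyl, the group on the neighbouring ring position of the printed structures is what separates them: 3,5-dimethylpiperazin-1-yl in place of 3-((ethylamino)methyl)pyrrolidin-1-yl gives an at least 4.1-fold higher number from compound 2 to compound 4 (0.61 log units; beyond the scatter), whereas 3,5-dimethylpiperazin-1-yl in place of pyrrolidin-1-yl gives an at least 1.7-fold higher number from compound 1 to compound 4 (0.25 log units; that floor lies within the scatter), and only the first of these is clearly beyond the scatter.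

The compounds shown leave open how far compound 3 and compound 4 lie past the limit, and so whether trifluoromethyl moves the number at all. They also leave open whether hydrogen, chloro or methoxy on this aromatic carbon, paired with 3-((ethylamino)methyl)pyrrolidin-1-yl, would give a number that could test the exchange directly.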